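Aryl amide variation on a shared core, one step measured

This account rests on a few compounds, and the source may have more. Where it says the series, first, only, none or still open, it means among the compounds named here.

Measured so far:
compound 1, `O=C(Nc1ccc(Cl)c(-c2nnc3c(Cl)cccn23)c1)c1ccc(F)cc1Cl`, > 100000 nM
compound 2, `O=C(Nc1ccc(Cl)c(-c2nnc3c(Cl)cccn23)c1)c1cccc(Cl)c1`, 54800 nM

In a functional assay on MDA-MB-468 cells (Homo sapiens) for antiproliferative activity, read by MTT assay, with a stated time of 72 h (a higher number here means a weaker inhibitor, a lower number a stronger inhibitor), compound 1 gives > 100000 nM, which is a limit of the assay and not a number. Compound 2 gives 54800 nM in this assay, the only number shown in the set. Among the compounds with values here, the one measured step, an at least 1.8-fold lower number from compound 1 to compound 2 (0.26 log units; that floor lies within the scatter), rests on the limit of > 100000 nM in this assay, at which 1 of the 2 values shown sits, and therefore gives only a floor that lies within the scatter.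

Compound 3 is `Cc1cc(Cl)ccc1C(=O)Nc1ccc(Cl)c(-c2nnc3c(Cl)cccn23)c1`. The change from compound 2 is 4-chloro-2-methylphenyl in place of 3-chlorophenyl on a carbonyl carbon. The measured step bears on it only loosely, as another exchange of the aryl group on the carbonyl carbon, and it was too small to show a direction beyond the scatter. No movement beyond the scatter is therefore expected, with a real chance that only a limit is reported. Compound 3 is estimated at 70000 nM, between 25000 nM and 200000 nM. The expected step is a 1.3-fold higher number from compound 2 to compound 3 (0.11 log units; within the scatter).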

Compound 3, half-maximal inhibitory concentration: 34300 nM
For compound 3 the middle estimate is 2.0-fold (0.31 log units) above the measured one; the measured number falls inside the stated range.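

Within the data shown here, the exchange to 4-chloro-2-methylphenyl on the carbonyl carbon gives the first step that clears the scatter in this assay, an at least 2.9-fold lower number from compound 1 to compound 3 (0.46 log units; beyond the scatter). That step is only a floor, since compound 1 stands at a limit of the assay and not at a number: the limit of > 100000 nM in this assay, at which 1 of the 3 values shown sits. Among these compounds, the only step between two real numbers is a 1.6-fold lower number from compound 2 to compound 3 (0.20 log units; within the scatter), so 3-chlorophenyl and 4-chloro-2-methylphenyl are not told apart at this position.

On these data alone, all three compounds carry a chlorine-bearing phenyl group on the carbonyl carbon, so it remains open how far this position can move the value at all. An amine, a carboxylic acid or a pyridine ring in place of that phenyl group would test this on the shared core.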